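Adding a second chloro to compound 2

A few compounds are considered here, and "the series" means these few. Any claim that something is new, unique, unknown or untested is made for them only; others in the source may bear on it.

In a functional assay on the whole organism for antagonist activity, with Mus musculus as the target, in the maximal electroshock model (on this read-out higher numbers stand for an effect only at larger amounts of compound and lower numbers for an effect already at smaller amounts), compound 2 (`COC(=O)NC1=NC(c2cccc(Cl)c2)CN1C`) gives 100 mg/kg, the higher of the two numbers, while compound 1 (`COC(=O)NC1=NC(c2ccccc2Cl)CN1C`) gives 28 mg/kg, a gap beyond the scatter. Compound 3 (`COC(=O)NC1=NC(c2cccc(Cl)c2Cl)CN1C`) has chloro in place of hydrogen on an aromatic carbon, ortho to a chloro group: chloro in place of hydrogen on an aromatic carbon. Within the data shown here, no measured pair differing in one place is available to size this change. Among the measured compounds shown here, with compound 1 at 28 mg/kg as the only lower number, a downward move is the working expectation. A moderate shift to a lower number is expected, slightly beyond the scatter: a 2.5-fold lower number from compound 2 to compound 3 (0.40 log units; beyond the scatter). For compound 3 the estimated value is 40 mg/kg, with an expected range of 15 mg/kg to 100 mg/kg.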

Compound 3, dose for half-maximal effect: 30 mg/kg
Beside the measured number, compound 3's estimate is 1.3-fold (0.12 log units) above it; the range from low to high includes it.
By their numbers in this assay, from the lowest: compounds 1 and 3 (each within the scatter of the next); then compound 2.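

In this assay, among these compounds, chloro on this aromatic carbon, ortho to a chloro group, gives a 3.3-fold lower number from compound 2 to compound 3 (0.52 log units; beyond the scatter), so the first measured step at this position lies beyond the scatter. Taken from the other chloro compound, the addition gives a 1.1-fold higher number from compound 1 to compound 3 (0.03 log units; within the scatter), so the size of the step depends on the compound it starts from. Nothing available explains either step.

As far as these compounds go, whether methoxy, methyl or an amine on this carbon would match chloro remains open.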